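The compounds below may be only part of what the source reports. "The series", "measured", "known", "first", "only" and "open" are said of these compounds alone.

Series notes, sulfonyl-indazole type core with a cyclic amine on the ring nitrogen.

Compound 1 `O=S(=O)(c1ccccc1F)c1cn(C2CCNC2)c2ncccc12` is the reference point. In an assay on HeLa cells for displacement of a labelled ligand from 5-hydroxytryptamine receptor 6 (Homo sapiens) (a higher number here means a weaker inhibitor, a lower number a stronger inhibitor), compound 1 gives 2 nM. Compound 2 `O=S(=O)(c1cccc(F)c1)c1cn(C2CCNC2)c2ncccc12` differs from it by 3-fluorophenyl in place of 2-fluorophenyl on a sulfonyl sulfur, and in this assay compound 2 gives 2.7 nM. The step from the one to the other is a 1.4-fold higher number from compound 1 to compound 2 (0.13 log units; within the scatter), so the two numbers cannot be told apart. Compound 3 `O=S(=O)(c1ccccc1F)c1cn(C2CCCNC2)c2ncccc12` keeps the 2-fluorophenyl of compound 1 and differs in the core by piperidin-3-yl in place of pyrrolidin-3-yl on an aromatic nitrogen; in this assay compound 3 gives 2 nM. That step is no change at the digits printed from compound 1 to compound 3 (within the scatter), and compound 3 and compound 1 together sit at the lowest of the three numbers, with compound 2 not separable from them.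

Compound 4 `O=S(=O)(c1cccc(F)c1)c1cn(C2CCCNC2)c2ncccc12` is not yet measured. Relative to compound 3 the difference is 3-fluorophenyl in place of 2-fluorophenyl on a sulfonyl sulfur. Going by the values given here, this is the same change as the one from compound 1 to compound 2, where it gave a 1.4-fold higher number from compound 1 to compound 2 (0.13 log units; within the scatter); the place lines of the two changes read the same word for word. The change occurs twice among the compounds shown, once measured and once not.

Among the compounds with values here, with only one measured example of the change, the expectation for compound 4 is that it repeats the small step seen before, so the estimated step is a 1.4-fold higher number from compound 3 to compound 4 (0.13 log units; within the scatter), resting on compound 3 at 2 nM and on the step of a 1.4-fold higher number from compound 1 to compound 2 (0.13 log units; within the scatter). Within the data shown here, compound 4 is therefore expected to come out near 2.7 nM, with a likely range from 1.3 nM to 6 nM, given how small the one measured instance of this change was.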

Compound 4, inhibition constant: 2.4 nM
Compound 4: middle estimate off by 1.1-fold (0.05 log units), on the high side; measured number inside the range.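

In this assay, 3-fluorophenyl in place of 2-fluorophenyl on a sulfonyl sulfur gives a 1.2-fold higher number from compound 3 to compound 4 (0.08 log units; within the scatter), and this agrees with the earlier instance of the same change: the same change on two cores in this assay, a 1.4-fold higher number (0.13 log units; within the scatter) from compound 1 to compound 2 and a 1.2-fold higher number (0.08 log units; within the scatter) from compound 3 to compound 4, 1.1-fold (0.05 log units) apart, within the scatter of two such steps. Piperidin-3-yl in place of pyrrolidin-3-yl on an aromatic nitrogen, read on the 3-fluorophenyl compounds, gives a 1.1-fold lower number from compound 2 to compound 4 (0.05 log units; within the scatter), and this also agrees with its earlier instance: the same change on two cores in this assay, no change at the digits printed (within the scatter) from compound 1 to compound 3 and a 1.1-fold lower number (0.05 log units; within the scatter) from compound 2 to compound 4, 1.1-fold (0.05 log units) apart, within the scatter of two such steps. Going by these compounds alone, both changes therefore carry from one core to the other in these four compounds, but every step involved lies within the scatter, so this shows only that neither change gave a separable step on either core, and it does not show that a step of clear size would carry over in the same way.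

Still open, on these data alone, is how the numbers would respond to a group other than a fluorophenyl on the sulfonyl sulfur, such as an unsubstituted phenyl or a methoxyphenyl. Equally open, as far as these compounds go, is what an open-chain aminoethyl group or an azetidine on the aromatic nitrogen would do in place of the pyrrolidin-3-yl and piperidin-3-yl rings.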